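The compounds below may be only part of what the source reports. "The series", "measured", "known", "first", "only" and "open" are said of these compounds alone.

Three compounds have been measured in an assay on membranes from liver for displacement of a labelled ligand from Sigma intracellular receptor 2 (Rattus norvegicus), read by scintillation counting, with a stated time of 120 min; a lower number here means a stronger inhibitor, a higher number a weaker inhibitor:

Compound 1 `Cc1cccc2sc(NC(=O)CCN3CCN(C(C)C)CC3)nc12` gives 1800 nM
Compound 2 `Cc1cccc2sc(NC(=O)CCN3CCN(C(C)(C)C)CC3)nc12` gives 200 nM
Compound 3 `CCCCN1CCN(CCC(=O)Nc2nc3c(C)cccc3s2)CC1` gives 1200 nM

Compound 3 sits close to compound 1, since a 1.5-fold lower number from compound 1 to compound 3 (0.18 log units; within the scatter), while compound 2 stands apart from both: a 6.0-fold higher number from compound 2 to compound 3 (0.78 log units; beyond the scatter), and a 9.0-fold lower number from compound 1 to compound 2 (0.95 log units; beyond the scatter). So far, all three compounds differ only in the group on the amine nitrogen of the six-membered ring, and only the tert-butyl group has moved the number beyond the scatter.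

Compound 4 `Cc1ccccc1N1CCN(CCC(=O)Nc2nc3c(C)cccc3s2)CC1` takes the step from compound 3 in that same place: 2-methylphenyl in place of butyl on an amine nitrogen in a ring. For the measured compounds named here, no measured step covers a change from a saturated chain to an aromatic ring at this position; the measured steps only compare one alkyl group with another, and they range from within the scatter to modest. The expectation therefore rests on weak ground. A modest lowering of the number is expected, so that a 3.0-fold lower number from compound 3 to compound 4 (0.48 log units; beyond the scatter). Compound 4 is estimated at 400 nM, with a range from 100 nM to 1500 nM.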

Compound 4, inhibition constant: > 1000 nM
Compound 4 gave a limit, no number; the forecaster's own chance of this, stated with the estimate: 5%; middle value at least 2.5-fold (0.39 log units) from the limit.
By their numbers in this assay, from the lowest: compound 2; then compounds 3 and 1 (each within the scatter of the next).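

Compound 4 gave only a limit, not a number: the limit of > 1000 nM in this assay, at which 1 of the 4 values shown sits.

Even so, one comparison can be read, and tert-butyl stays ahead of the aromatic group at this position, with an at least 5.0-fold higher number from compound 2 to compound 4 (0.69 log units; beyond the scatter). For the compounds shown here, this is the first sign that 2-methylphenyl on this amine nitrogen does not keep the low number seen with tert-butyl, although the steps to compound 4 from compound 1 and compound 3 cannot be read, so it stays unknown how this group compares with isopropyl or butyl.

With 2-methylphenyl as the only aromatic group shown, it remains open whether a plain phenyl or a benzyl on this nitrogen would end up any differently. From the compounds shown here alone, it is equally open whether a cyclohexyl, another bulky saturated group, would come close to compound 2 at 200 nM.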